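Methyl removal on the shared core: compound 2 to compound 4

This account rests on a few compounds, and the source may have more. Where it says the series, first, only, none or still open, it means among the compounds named here.

Measured so far:
- compound 1, `Cc1ccnc2nc(-c3ccc(F)cc3)cc(O)c12`: 33900 nM
- compound 2, `COc1ccccc1-c1cc(O)c2cc(C)cnc2n1`: 41700 nM
- compound 3, `Cc1cnc2nc(-c3ccc(F)cc3)cc(O)c2c1`: 32400 nM

All three numbers come from a functional assay on 786-0 cells (Homo sapiens); a lower number here means a stronger inhibitor of growth, a higher number a weaker inhibitor of growth. Compound 2, 41700 nM, gives the largest of the three numbers, but the gap to compound 1 and the gap to compound 3 both lie within the scatter, so the three compounds cannot be separated on these data.

Compound 4, `COc1ccccc1-c1cc(O)c2cccnc2n1`, has not yet been run in this assay. It differs from compound 2 in one place: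
hydrogen in place of methyl on an aromatic carbon

Among the measured compounds shown here, no pair among the measured compounds differs by this change, so the set holds no measured step for it. For the measured compounds named here, with all three known numbers sitting close together and no step to lean on, the expected step of a 1.1-fold higher number from compound 2 to compound 4 (0.03 log units; within the scatter) for compound 4 is none beyond the scatter. Compound 4 is therefore estimated at 45000 nM in this assay, with a range from 15000 nM to 135000 nM.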

Compound 4, concentration for 50% growth inhibition: 36300 nM
Beside the measured number, compound 4's estimate is 1.2-fold (0.09 log units) above it; low and high end bracket the measured number.
By their numbers in this assay, from the lowest: compounds 3, 1, 4 and 2 (each within the scatter of the next).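

In this assay, hydrogen in place of methyl on an aromatic carbon, two atoms from the ring nitrogen, gives a 1.1-fold lower number from compound 2 to compound 4 (0.06 log units; within the scatter). Among the compounds shown here, this is the first measured step, and it shows that, on the core of compound 2, the methyl at this position can be lost with no difference that stands clear of the scatter. No measured property or other outside data bear on this step.

Going by these compounds, the step comes from a single pair, so whether the same change behaves alike on the core of compound 3 remains open. Also open, on these data alone, is whether a different group on this aromatic carbon, such as an amine, a carboxylic acid or a longer alkyl chain, would move the number in this assay beyond the scatter.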